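The source may report more compounds than this note shows. Statements on the series, on what has been measured and on what is new or still open speak of the compounds shown alone.

Measured in a functional assay on NT2 cells (Homo sapiens) for inhibition; on this read-out higher numbers stand for weaker inhibition and lower numbers for stronger inhibition:
- Compound 1 `CCC(C(=O)N[C@@H](CC(=O)O)C(=O)CNCN1CCCC1)n1ccnc(NCc2nonc2C)c1=O` gives 0.84 nM
- Compound 2 `CCC(C(=O)N[C@H](C=O)CC(=O)O)n1ccnc(NCc2nonc2C)c1=O` gives 3.56 nM

Compound 1, at 0.84 nM, holds the lower of the two numbers. Compound 3 `CCC(C(=O)N[C@@H](CC(=O)O)C(=O)CNCN1CCc2ccccc2C1)n1ccnc(NCc2nonc2C)c1=O` differs from it in one group, as follows: 1,2,3,4-tetrahydroisoquinolin-2-yl in place of pyrrolidin-1-yl on a saturated chain carbon bound to an amine nitrogen. Among the measured compounds shown here, only one measured step bears on this change, and it is modest: a 4.2-fold higher number from compound 1 to compound 2 (0.63 log units; beyond the scatter). That step takes away the whole chain carrying the pyrrolidin-1-yl, whereas compound 3 keeps the chain and exchanges only the ring. In this assay no shift beyond the scatter is therefore expected, and the expected step is a 1.2-fold higher number from compound 1 to compound 3 (0.08 log units; within the scatter). Compound 3 is estimated at 1 nM with an expected range from 0.3 nM to 3.5 nM overall.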

Compound 3, half-maximal inhibitory concentration: 1.25 nM
Compound 3: middle estimate off by 1.3-fold (0.10 log units), on the low side, within the range that was stated.
By their numbers in this assay, from the lowest: compounds 1 and 3 (each within the scatter of the next); then compound 2.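

In this assay, the change to 1,2,3,4-tetrahydroisoquinolin-2-yl gives a 1.5-fold higher number from compound 1 to compound 3 (0.17 log units; within the scatter). The earlier step removed the whole chain, whereas this one exchanges only the ring, and it shows that 10 heavy atoms, including an added aromatic ring, can stand in place of 5 on this saturated chain carbon with no shift beyond the scatter. Nothing measured here explains this result. Still open, on these data alone, is how the number would respond to a piperazin-1-yl ring or an open-chain dimethylamino group in this place, or to a chlorine on the aromatic ring of the 1,2,3,4-tetrahydroisoquinolin-2-yl group.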